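The source may hold more compounds than are shown below. What is called first, only, known or untested is meant among the compounds shown, and "the series" means these compounds.

Within the data shown here, compound 2 `CC(C)c1ccccc1OS(=O)(=O)c1ccc(NC(=O)CCCl)cc1` is one of only two compounds so far measured in a functional assay on HT-29 cells (Homo sapiens) for antiproliferative activity, read by sulforhodamine B assay, with a stated time of 48 h (a lower number here means a stronger inhibitor, a higher number a weaker inhibitor), where compound 2 gives 16000 nM. Its companion is compound 1 `CC(=O)Nc1ccc(S(=O)(=O)Oc2ccccc2C(C)C)cc1`, which in this assay gives 23000 nM. Among the measured compounds shown here, the single step between the measured pair, a 1.4-fold lower number from compound 1 to compound 2 (0.16 log units; within the scatter), lies within the scatter, so compound 2 holds the lowest of the two numbers without the data separating it from compound 1. Compound 3 `CC(C)c1ccccc1OS(=O)(=O)c1ccc(NC(=O)CCCCl)cc1` differs from compound 2 by one change: chloromethyl in place of chloro on a saturated chain carbon, two bonds along the chain from a carbonyl carbon. For the measured compounds named here, the only measured step that bears on this is the earlier lengthening of the same chain, a 1.4-fold lower number from compound 1 to compound 2 (0.16 log units; within the scatter), which moved nothing beyond the scatter. On that basis a further lengthening of the chain is expected to leave this assay close to where compound 2 stands, with no step in either direction beyond the scatter, and the expected step is a 1.1-fold lower number from compound 2 to compound 3 (0.03 log units; within the scatter). Compound 3 is therefore estimated at 15000 nM, with a range from 6000 nM to 40000 nM, pending the actual measurement.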

Compound 3, half-maximal inhibitory concentration: 6200 nM
Compound 3: middle estimate off by 2.4-fold (0.38 log units), on the high side, within the range that was stated.
By their numbers in this assay, from the lowest: compound 3; then compounds 2 and 1 (each within the scatter of the next).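

In this assay, among these compounds, the change to chloromethyl in place of chloro on a saturated chain carbon, two bonds along the chain from a carbonyl carbon, gives a 2.6-fold lower number from compound 2 to compound 3 (0.41 log units; beyond the scatter) and is the first step in this small set to pass beyond the scatter, though it remains modest. Among the compounds shown here, compound 3 also separates from the compound with no chlorinated chain, with a 3.7-fold lower number from compound 1 to compound 3 (0.57 log units; beyond the scatter), so this chain position does affect the number in this assay even though the first step among the compounds did not show it. Nothing available explains why the longer chlorinated chain gives the lower number.

The compounds shown leave open whether the trend would continue with a longer chain such as 4-chlorobutyl or would reverse there. They also leave open whether the chlorine itself matters at the end of the chain, which a plain propyl group, a bromine or a hydroxyl in its place would test.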